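(4-Methylphenyl)sulfonyl in place of benzoyl on compound 2

This account rests on a few compounds, and the source may have more. Where it says the series, first, only, none or still open, it means among the compounds named here.

Measured so far, in a functional assay on HepG2 cells (Homo sapiens) for cytotoxicity, read by MTT assay, with a stated time of 48 h; a lower number here means a stronger inhibitor, a higher number a weaker inhibitor:
Compound 1 `CCCCCCCCNC(=O)[C@@H](NC(=O)c1ccccc1)[C@@H](C)O` gives 136000 nM.
Compound 2 `CCCCCCCCCCCCNC(=O)[C@@H](NC(=O)c1ccccc1)[C@@H](C)O` gives only a limit of the assay, > 400000 nM.
Compound 3 `CCCCCCCCCCCCNC(=O)[C@@H](NC(=O)c1cc2ccccc2o1)[C@@H](C)O` gives 22900 nM.
Compound 4 `CCCCCCCCCCCCNC(=O)[C@@H](NS(=O)(=O)c1ccc(C)cc1)[C@@H](C)O` is not yet measured.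

Compound 2 stands at the weak end of the three: its result is a limit, (the limit of > 400000 nM in this assay, at which 1 of the 3 values shown sits), so no number is known for it. The change to compound 4 is (4-methylphenyl)sulfonyl in place of benzoyl on an amine nitrogen. Neither measured step touches this place in the same way. The step of an at least 2.9-fold higher number from compound 1 to compound 2 (0.46 log units; beyond the scatter) concerns the chain, not the nitrogen substituent. The step of an at least 17-fold lower number from compound 2 to compound 3 (1.24 log units; beyond the scatter) does alter the group on the carbonyl carbon, and it was large, which shows that this part of the molecule can move the number considerably in this assay. An exchange of benzoyl for (4-methylphenyl)sulfonyl is a different kind of change, so the expected step of an at least 1.6-fold lower number from compound 2 to compound 4 (0.20 log units; that floor lies within the scatter) is set as modest and downward, with wide uncertainty. Compound 4 is therefore estimated at 250000 nM in this assay, within 60000 nM to 400000 nM, and a result that is again only a limit remains likely.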

Compound 4, half-maximal inhibitory concentration: 25800 nM
Compound 4: middle estimate off by 9.7-fold (0.99 log units), on the high side; the whole stated range lies above it.
By their numbers in this assay, from the lowest: compounds 3 and 4 (each within the scatter of the next); then compound 1. At a limit, above all of these: compound 2.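

In this assay, the exchange on the amine nitrogen gives an at least 15-fold lower number from compound 2 to compound 4 (1.19 log units; beyond the scatter), so this position tolerates more than carbonyl-linked groups, and a sulfonyl link with a simple substituted phenyl ring is enough to bring a clear response. The earlier step at this end of the molecule kept the carbonyl and changed only the ring, whereas here the carbonyl itself is gone. With the long chain held constant, compound 3 gives 22900 nM and compound 4 gives 25800 nM, values within the scatter of each other, so the two replacements for benzoyl cannot be ranked. The figure for compound 2 is only a limit: the limit of > 400000 nM in this assay, at which 1 of the 4 values shown sits.

On these data alone, it remains open how much of the step belongs to the sulfonyl link and how much to the methyl on the ring, a question that phenylsulfonyl or methanesulfonyl on the amine nitrogen would address. Whether (4-methylphenyl)sulfonyl acts the same way on the shorter chain of compound 1 is also unresolved.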